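Hydrogen in place of methyl in compound 2

The compounds below may be only part of what the source reports. "The series", "measured", "known", "first", "only" and "open" are said of these compounds alone.

Within the data shown here, in a functional assay on COLO 205 cells (Homo sapiens) for inhibition, read by sulforhodamine B assay (a lower number here means a stronger inhibitor of growth, a higher number a weaker inhibitor of growth), compound 2 `COc1cc(-c2ccc(-c3ccc(-c4nc5cc(C)ccc5[nH]4)cc3)cc2)cc(OC)c1OC` gives 190 nM, the lowest of the three numbers so far. Compound 1 `COc1ccc(-c2ccc(-c3ccc(-c4nc5cc(C)ccc5[nH]4)cc3)cc2)cc1OC` gives 2320 nM, and compound 3 `COc1ccc(-c2ccc(-c3ccc(-c4nc5ccccc5[nH]4)cc3)cc2)cc1` gives 45200 nM.

Compound 4 `COc1cc(-c2ccc(-c3ccc(-c4nc5ccccc5[nH]4)cc3)cc2)cc(OC)c1OC` has not been measured. Its difference from compound 2 is hydrogen in place of methyl on an aromatic carbon.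

Among the measured compounds shown here, no measured step isolates this change. For the measured compounds named here, the one measured step, a 12-fold lower number from compound 1 to compound 2 (1.09 log units; beyond the scatter), is large, but it is methoxy in place of hydrogen on an aromatic carbon, and the methyl stays in both compounds. Compound 3 lacks the methyl, but it also has one methoxy fewer than compound 1, so the higher number of compound 3 carries both changes together. It offers only a weak hint of direction.

In this assay the expected step is a 2.6-fold higher number from compound 2 to compound 4 (0.42 log units; beyond the scatter), a moderate move to a higher number with wide uncertainty. For compound 4 the estimate is 500 nM, with an expected range of 130 nM to 2500 nM.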

Compound 4, concentration for 50% growth inhibition: 8320 nM
Compound 4: the middle estimate sits 17-fold (1.22 log units) below what was measured; measured number outside the range, above it.
By their numbers in this assay, from the lowest: compound 2; then compound 1; then compound 4; then compound 3.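

In this assay the change from 5-methyl-1H-benzimidazol-2-yl to 1H-benzimidazol-2-yl now has a step of its own, a 44-fold higher number from compound 2 to compound 4 (1.64 log units; beyond the scatter), so a single methyl carbon on this aromatic ring carries much of the standing of compound 2. Among these compounds, the methoxy step, a 12-fold lower number from compound 1 to compound 2 (1.09 log units; beyond the scatter), is therefore no longer the only large single change, and the two changes sit at opposite ends of the molecule. No data given here bear on why the methyl matters this much.

From the compounds shown here alone, the methyl step is read only with the methoxy groups of compound 2 in place, so its size with the methoxy groups of compound 1 remains open. Also open, going by these compounds, is whether an ethyl group, a chlorine atom or an amine at this position would behave like the methyl.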